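Swapping the Amide of Compound 2 for an Oxadiazole

The source may hold more compounds than are shown below. What is called first, only, known or untested is meant among the compounds shown, and "the series" means these compounds.

Of the compounds shown here, three sharing one core have been tested in a functional assay on MIA PaCa-2 cells (Homo sapiens) for inhibition, read by MTT assay, with a stated time of 3 days; a higher number here means a weaker inhibitor, a lower number a stronger inhibitor. Compound 1 `CCN(CC)S(=O)(=O)c1ccc(S(=O)(=O)N2CCC[C@@H](C(=O)N(C)C(C)C)C2)cc1` gives 1400 nM in this assay. Compound 3 `CCN(CC)S(=O)(=O)c1ccc(S(=O)(=O)N2CCC[C@@H](C(=O)NC3CN(C(=O)NC(C)(C)C)C3)C2)cc1` gives 1400 nM. For compound 2 `CCN1CC(NC(=O)[C@@H]2CCCN(S(=O)(=O)c3ccc(S(=O)(=O)N(CC)CC)cc3)C2)C1` the assay gives only a limit, > 10000 nM, so its number is not known and it stands at the weak edge of the measured set (the limit of > 10000 nM in this assay, at which 1 of the 3 values shown sits). The steps tell how much the group on the carbonyl carbon matters: an at least 7.1-fold higher number from compound 1 to compound 2 (0.85 log units; beyond the scatter), whereas no change at the digits printed from compound 1 to compound 3 (within the scatter), and an at least 7.1-fold lower number from compound 2 to compound 3 (0.85 log units; beyond the scatter).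

Compound 4 `CCN(CC)S(=O)(=O)c1ccc(S(=O)(=O)N2CCC[C@@H](c3nc(C)no3)C2)cc1` has not yet been measured. It differs from compound 2 in one place, (3-methyl-1,2,4-oxadiazol-5-yl in place of (1-ethylazetidin-3-yl)carbamoyl on a saturated ring carbon); the whole carbonyl and its azetidine amine are gone and a small aromatic ring sits directly on the saturated ring carbon. Among the measured compounds shown here, no measured step removes the amide itself, so the closest guides are the two steps that leave compound 2, both of which show that changing this region moves the number beyond the scatter. Since two of three compounds with an amide here sit near the number of compound 1, compound 4 is expected to land near that region, a step of an at least 3.3-fold lower number from compound 2 to compound 4 (0.52 log units; beyond the scatter), with an estimate of 3000 nM and a range from 800 nM to 12000 nM.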

Compound 4, half-maximal inhibitory concentration: 700 nM
Estimate against measurement, compound 4: 4.3-fold (0.63 log units) above; measured number outside the range, below it.
By their numbers in this assay, from the lowest: compounds 4, 1 and 3 (each within the scatter of the next). At a limit, above all of these: compound 2.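

An amide on this saturated ring carbon is not needed for activity in this assay. With the carbonyl and amide nitrogen gone, replacing the isopropyl(methyl)carbamoyl group with 3-methyl-1,2,4-oxadiazol-5-yl gives a 2.0-fold lower number from compound 1 to compound 4 (0.30 log units; within the scatter), so a small aromatic ring can stand in for that amide. Replacing the (1-ethylazetidin-3-yl)carbamoyl group with the same ring gives an at least 14-fold lower number from compound 2 to compound 4 (1.15 log units; beyond the scatter), which leaves compound 2 as the only one of the four compounds apart from the rest, and the size of that step is bounded by a limit of the assay: the limit of > 10000 nM in this assay, at which 1 of the 4 values shown sits.

On these data alone, it remains open whether this result depends on the oxadiazole ring itself or simply on the loss of the amide, and a plain phenyl ring or a 1,3,4-oxadiazole at the same carbon would help separate those two readings. The compounds shown also leave open how much the methyl on the oxadiazole matters, and what a longer chain or an amine in its place would do to the number.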